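This account rests on a few compounds, and the source may have more. Where it says the series, first, only, none or still open, it means among the compounds named here.

Compound 1 `Cc1ccc(CN2CCc3c(c(=O)n(CC4NCCc5ccccc54)c(=O)n3Cc3c(F)cccc3F)C2)c(C)c1` is the reference for this step. In an assay on isolated protein for inhibition of Gonadotropin-releasing hormone receptor (Homo sapiens) (a higher number here means a weaker inhibitor, a lower number a stronger inhibitor), compound 1 gives 110 nM, the second highest of the three numbers seen so far. Compound 2 `CC(CCN1CCc2c(c(=O)n(CCN3CCCCC3)c(=O)n2Cc2c(F)cccc2F)C1)CC(C)(C)C` gives 4400 nM, higher than compound 1 beyond the scatter, while compound 3 `CNCCNc1nc(OC)c(NC(=O)c2ccc(Cc3cc4c(cc3C)C(C)(C)OC4(C)C)o2)c(OC)n1` gives 1 nM, far lower. Compound 4 `Cc1ccc(CN2CCc3c(c(=O)n(CC4CCNCC4)c(=O)n3Cc3c(F)cccc3F)C2)c(C)c1` awaits measurement; it differs from compound 1 in one place: piperidin-4-yl in place of 1,2,3,4-tetrahydroisoquinolin-1-yl on a saturated chain carbon bound to an aromatic nitrogen. Among the compounds with values here, no measured pair shows this exact change, so the size of the step is uncertain. Compound 2, which carries a different saturated amine chain at the same nitrogen together with other changes, gives the weakest number here, so a step toward a weaker inhibitor, a 2.7-fold higher number from compound 1 to compound 4 (0.44 log units; beyond the scatter), is expected. Compound 4 is estimated at 300 nM, within 70 nM to 1500 nM.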

Compound 4, inhibition constant: 1900 nM
Compound 4: middle estimate off by 6.3-fold (0.80 log units), on the low side; the whole stated range lies below it.
By their numbers in this assay, from the lowest: compound 3; then compound 1; then compound 4; then compound 2.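

Within the data shown here, at this position, on a saturated chain carbon bound to an aromatic nitrogen, replacing 1,2,3,4-tetrahydroisoquinolin-1-yl with piperidin-4-yl gives the first single-place step in this assay: a 17-fold higher number from compound 1 to compound 4 (1.24 log units; beyond the scatter). The position is therefore sensitive to this exchange, although the six-membered non-aromatic ring and the hydrogen-bond donor and acceptor counts are unchanged while the six-membered aromatic ring is lost. Nothing available explains the size of this step.

The compounds shown do not separate loss of the aromatic ring from the different point of attachment. A piperidin-4-yl carrying a phenyl group would test whether restoring an aromatic ring recovers the lost ground.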